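The source may hold more compounds than are shown below. What is called first, only, known or untested is meant among the compounds shown, and "the series" means these compounds.

The study concerns a set of polyene esters and amides built on the shared core of compound 1, whose structure is `CCOC(=O)/C=C(C)/C(F)=C/C(F)=C(C)/C=C/c1c(C)cc(OC)c(C)c1C`. In a functional assay on the whole organism (strain Hart Swiss) with Mus musculus as the target, with stated times of 5 days and 2 weeks, at a dose of 80 mg/kg by the intraperitoneal route (on this read-out lower numbers stand for a weaker effect and higher numbers for a stronger effect at the one dose given), compound 1 gives 33%. Two further compounds share this core. Compound 2, with the structure `CCNC(=O)/C=C(C)/C=C/C(F)=C(C)/C=C/c1c(C)cc(OC)c(C)c1C`, gives 53% in this assay, and compound 3, with the structure `COC(=O)/C=C(C)/C=C/C=C(\C=C\c1c(C)cc(OC)c(C)c1C)C(F)(F)F`, gives 25%. Among these three numbers compound 1 stands second highest: the result for compound 3 lies within the usual scatter of that for compound 1, so the two cannot be ordered, while the result for compound 2 lies higher by a gap beyond the scatter.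

The step now considered leads from compound 1 to compound 4, whose structure is `CCOC(=O)/C=C(C)/C(F)=C/C=C(C)/C=C/c1c(C)cc(OC)c(C)c1C` and which has not yet been measured in this assay. The change is hydrogen in place of fluoro on a double-bonded chain carbon bound to two double-bonded chain carbons. Among the compounds with values here, no step between two measured compounds isolates this change, so its size has to be judged from what the three values show. Compound 2, which also lacks fluoro at such a carbon, gives 53%, but it differs from compound 1 in other places as well.

For this assay the step from compound 1 to compound 4 is expected to be small, a number 5 percentage points higher from compound 1 to compound 4 (within the scatter), not clearly beyond the scatter. Compound 4 is therefore estimated at 38%, with a range from 18% to 58%.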

Compound 4, a percentage reported as activity, at one dose (the size of the read-out at that dose, not a potency): 82%
The estimate for compound 4 lay 44 percentage points below the measured number; measured number outside the range, above it.
By their numbers in this assay, from the lowest: compounds 3 and 1 (each within the scatter of the next); then compound 2; then compound 4.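

In this assay, putting hydrogen in place of fluoro on a double-bonded chain carbon bound to two double-bonded chain carbons gives a number 49 percentage points higher from compound 1 to compound 4 (beyond the scatter), so in compound 1 the read-out at the one dose given depends strongly on what this carbon carries. The earlier compounds shown here could not show this: compounds 1, 2 and 3 differ from one another in more than one place, whereas this step changes a single atom and leaves the rest of compound 1 as it stands, which makes it the first isolated measure of any change in this set. Nothing available accounts for the size of this step, and its cause remains unknown.

As far as these compounds go, it remains open whether this large step belongs to hydrogen alone or would also appear with another group on this carbon, such as a chloro or a methyl group. Also open, from the compounds shown here alone, is whether the step would keep its size if the ethyl ester of compound 1 gave way to a carboxylic acid, or if the other fluoro, still present in compound 4, were replaced by hydrogen as well.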